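Reversing the sulfonamide on the shared core

The compounds below may be only part of what the source reports. "The series", "measured", "known", "first", "only" and "open" are said of these compounds alone.

Of the compounds shown here, three built on one core have been tested in an in vitro ADME assay on microsomes from liver (Homo sapiens) for metabolic stability; a higher number here means faster removal of the compound, a lower number slower removal. Compound 1 `COc1ccc(-c2cc(-c3ccc(S(=O)(=O)N(C)C)cc3)cnc2N)cn1` gives 98.8 mL.min-1.g-1. Compound 3 `COc1ccc(-c2cc(-c3ccc(S(=O)(=O)NC4CC4)cc3)cnc2N)cn1` gives 15 mL.min-1.g-1, the lowest of the two plain numbers, with a 6.6-fold lower number from compound 1 to compound 3 (0.82 log units; beyond the scatter). Compound 2 `COc1ccc(-c2cc(-c3ccc(S(N)(=O)=O)cc3)cnc2N)cn1` returns only a limit of the assay, < 7 mL.min-1.g-1. Against that limit, an at least 14-fold lower number from compound 1 to compound 2 (1.14 log units; beyond the scatter) and an at least 2.1-fold higher number from compound 2 to compound 3 (0.33 log units; beyond the scatter) are seen.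

Compound 4 `COc1ccc(-c2cc(-c3ccc(NS(C)(=O)=O)cc3)cnc2N)cn1` differs from compound 3 in one place: methanesulfonamido in place of cyclopropylsulfamoyl on an aromatic carbon. Within the data shown here, none of the measured steps covers this reversal of the sulfonamide; the closest is the exchange of cyclopropyl for hydrogen on a sulfonamide nitrogen between compound 2 and compound 3, which was at least modest, and compound 4 keeps one hydrogen on its nitrogen. The expectation for no change at the digits printed from compound 3 to compound 4 (within the scatter) is therefore a step no larger than the scatter, in no firm direction. Compound 4 is estimated at 15 mL.min-1.g-1, between 7 mL.min-1.g-1 and 40 mL.min-1.g-1, in this assay.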

Compound 4, intrinsic clearance in microsomes: < 7 mL.min-1.g-1
Compound 4: no number, only a limit (the forecaster's own chance of this, stated with the estimate: 25%); middle value at least 2.1-fold (0.33 log units) from the limit.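

In this assay, compound 4 returns only a limit, < 7 mL.min-1.g-1. Methanesulfonamido in place of cyclopropylsulfamoyl brings an at least 2.1-fold lower number from compound 3 to compound 4 (0.33 log units; beyond the scatter), and methanesulfonamido in place of dimethylsulfamoyl brings an at least 14-fold lower number from compound 1 to compound 4 (1.14 log units; beyond the scatter), so at this place, on an aromatic carbon para to a large group, slow removal is no longer tied to a sulfamoyl group: the reversed sulfonamide, with its nitrogen on the aromatic carbon, shows it as well. The step from compound 2 to compound 4 cannot be read because both compounds stand at a limit: the limit of < 7 mL.min-1.g-1 in this assay, at which 2 of the 4 values shown sit.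

The compounds shown leave open whether the hydrogen on the nitrogen of compound 4 matters, since no methyl group takes its place there. They also do not show how ethanesulfonamido or a carboxylic acid at this place would behave in this assay.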